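The source may report more compounds than this note shows. Statements on the series, on what has been measured and on what is new or still open speak of the compounds shown alone.

In an ADME assay on HEK293 cells (Homo sapiens) for cytotoxicity, read by CellTiter-Glo and resazurin assay, with a stated time of 72 h (on this read-out higher numbers stand for an effect only at larger amounts of compound and lower numbers for an effect already at smaller amounts), the measured compounds read as follows. Compound 1 `Cc1nnc(-c2cccc(-c3ccc(C(=O)N(Cc4cccc(OCCCCCC(=O)O)c4)C(C)C)cc3)c2)o1` gives > 26000 nM, which is a limit of this assay and not a number. Compound 2 `CCOC(=O)CCCCCOc1cccc(CN(C(=O)c2ccc(-c3ccncc3)cc2)C(C)C)c1` gives > 26000 nM, again a limit. Compound 3 `CCOC(=O)CCCCCOc1cccc(CN(C(=O)c2ccc(-c3cccc(OC(C)C)c3)cc2)C(C)C)c1` gives > 26000 nM, also a limit.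

Compound 3 therefore stands where every measured value stands, at the limit of > 26000 nM in this assay, at which 3 of the 3 values shown sit. Among the compounds with values here, the only single-point step available, a step that the two limits leave unreadable from compound 2 to compound 3, cannot be read because both ends are limits.

Compound 4 `CCOC(=O)CCCCCOc1cccc(CN(C(=O)c2ccc(-c3cccc(-c4nnc(C)o4)c3)cc2)C(C)C)c1` differs from compound 3 by 5-methyl-1,3,4-oxadiazol-2-yl in place of isopropoxy on an aromatic carbon. Within the data shown here, no measured step bears readably on this change. The expectation for compound 4 in this assay is a limit again, with an estimated step that the limit leaves unreadable from compound 3 to compound 4 that would not stand out from the scatter. The estimated value for compound 4 is 30000 nM, in a range from 18000 nM to 60000 nM.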

Compound 4, half-maximal effective concentration: > 26000 nM
Compound 4 ended at the assay's limit; the forecaster's own chance of this, stated with the estimate: 85%; the middle value does not contradict the limit.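

The steps linking compound 4 to compound 1, compound 2 and compound 3 cannot be read in this assay, because both ends of each are limits: the limit of > 26000 nM in this assay, at which 4 of the 4 values shown sit. The compounds shown leave open at what concentration any of them reaches a half-maximal effect, and whether their structural differences change it.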